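The source may report more compounds than this note shows. Statements on the series, on what has been measured and on what is new or still open speak of the compounds shown alone.

Of the compounds shown here, three sharing one core have been measured in an assay on CHO cells for inhibition of metabotropic glutamate receptor 1 (Rattus norvegicus); on this read-out higher numbers stand for weaker inhibition and lower numbers for stronger inhibition. Compound 1 `CCCOC(=O)c1[nH]c(COC(C)=O)c(C(=O)OC(C)(C)C)c1C` gives 2700 nM, compound 2 `CCN1CCC(OC(=O)c2[nH]cc(C(=O)OC(C)C(C)(C)C)c2C)C1` gives 260 nM, and compound 3 `C=CCOC(=O)Cn1c(C)c(C(=O)OC(C)(C)C)c(C)c1C(=O)OCCC` gives 12600 nM. Among these three numbers compound 2 stands lowest: compound 1 is the nearest to it, with a value higher by a gap that lies beyond the usual scatter, and compound 3 is the furthest, with a gap also beyond the scatter. Compound 4 `CCCOC(=O)c1[nH]cc(C(=O)OC(C)C(C)(C)C)c1C` has not yet been measured in this assay. Its difference from compound 2 is a single one: propyl in place of 1-ethylpyrrolidin-3-yl on an oxygen next to a carbonyl group. Among the measured compounds shown here, no pair of measured compounds differs in only this way, so there is no measured step to lean on; compound 1 does carry propyl on the corresponding oxygen, but it differs from compound 2 in other places too. For the measured compounds named here, the value of compound 1, 2700 nM, shows only that a propyl ester of this core can sit well above the lowest number measured so far. The step from compound 2 to compound 4 is expected to be upward by a 4.6-fold higher number from compound 2 to compound 4 (0.66 log units; beyond the scatter), a change beyond the scatter. For compound 4 the expected value in this assay is 1200 nM, within a range from 300 nM to 5000 nM.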

Compound 4, half-maximal inhibitory concentration: 4 nM
Beside the measured number, compound 4's estimate is 300-fold (2.48 log units) above it, and the stated range ends above it.
By their numbers in this assay, from the lowest: compound 4; then compound 2; then compound 1; then compound 3.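

Among the compounds shown here, on an oxygen next to a carbonyl group, the earlier compounds offered no pair differing in that place alone, and this pair now gives a direct reading in this assay. Propyl in place of 1-ethylpyrrolidin-3-yl produces a 65-fold lower number from compound 2 to compound 4 (1.81 log units; beyond the scatter) and so shows that the group at this position can change the read-out greatly, with the smaller, ring-free propyl giving the lower number. Nothing measured here explains why the step is so large.

This single change removes the ring, the nitrogen and several heavy atoms at once, so the compounds shown do not tell which of these matters. Cyclopentyl would keep a five-membered ring without the nitrogen, while butyl or a longer chain would show how the read-out follows chain length at this position.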